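The source may report more compounds than this note shows. Statements on the series, on what has been measured and on what is new or still open speak of the compounds shown alone.

Measured so far in a functional assay on cells (Rhabdomyosarcoma cell, Homo sapiens) for cytotoxicity; on this read-out lower numbers stand for stronger inhibition and higher numbers for weaker inhibition:

Compound 1, `Cc1ccsc1C(c1ccccc1)N1CCN(c2ncnc3c2cnn3-c2ccccc2)CC1`, gives > 25000 nM, which is a limit of this assay rather than a number.
Compound 2, `c1ccc(C(c2ccco2)N2CCN(c3ncnc4c3cnn4-c3ccccc3)CC2)cc1`, gives > 25000 nM, again a limit of this assay.
Compound 3, `c1ccc(C(c2nccs2)N2CCN(c3ncnc4c3cnn4-c3ccccc3)CC2)cc1`, gives > 25000 nM, also a limit of this assay.

Compound 2 therefore stands at the limit of this assay, and so do the two other measured compounds, as the limit of > 25000 nM in this assay, at which 3 of the 3 values shown sit, records. The steps among them, a step that the two limits leave unreadable from compound 1 to compound 2, a step that the two limits leave unreadable from compound 1 to compound 3 and a step that the two limits leave unreadable from compound 2 to compound 3, cannot be sized, since both ends of each step are limits.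

Compound 4 is `FC(F)(F)c1ccc(C(c2ccccc2)N2CCN(c3ncnc4c3cnn4-c3ccccc3)CC2)cc1`. It differs from compound 2 by 4-(trifluoromethyl)phenyl in place of furan-2-yl on a saturated chain carbon bound to an amine nitrogen in a ring and an aromatic carbon. For the measured compounds named here, none of the measured steps puts a number on a change of this kind, so the only guide is that every measured compound sits at the limit in this assay. The expectation for compound 4 is therefore a step that the limit leaves unreadable from compound 2 to compound 4, which amounts to no readable change, with the result most likely to come back as a limit again. The estimated value for compound 4 in this assay is 30000 nM, within a range from 8000 nM to 120000 nM.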

Compound 4, half-maximal inhibitory concentration: > 25000 nM
Compound 4: only a limit was reported; the forecaster's own chance of this, stated with the estimate: 80%; the middle value does not contradict the limit.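

Compound 4 gives only a limit in this assay as do compound 1, compound 2 and compound 3, so no step among these compounds can be read: the limit of > 25000 nM in this assay, at which 4 of the 4 values shown sit. The compounds shown leave open whether changing the group on the saturated chain carbon alters cytotoxicity at all.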